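A Chlorine Moved From the Phenyl to the Core

The compounds below may be only part of what the source reports. "The series", "measured", "known", "first", "only" and "open" are said of these compounds alone.

Compound 1 `O=C(O)CCCCCOc1cc(-c2ccccc2)c2ccccc2n1` is tested in an assay on membranes from spleen (Cavia porcellus) for binding affinity to leukotriene B4 receptor 1 (Homo sapiens) (a higher number here means a weaker inhibitor, a lower number a stronger inhibitor), where compound 1 gives 700 nM. Compound 2 `CC(C)(CCCCOc1cc(-c2ccccc2)c2ccccc2n1)C(=O)O` differs from it by 1-carboxy-1-methylethyl in place of carboxymethyl on a saturated chain carbon, four bonds along the chain from an oxygen on an aromatic ring; in this assay compound 2 gives 183 nM, a step of a 3.8-fold lower number from compound 1 to compound 2 (0.58 log units; beyond the scatter). Compound 3 `O=C(O)CCCCCOc1cc(-c2ccc(Cl)cc2)c2ccccc2n1` carries chloro in place of hydrogen on an aromatic carbon; in this assay compound 3 gives 30 nM, the step being a 23-fold lower number from compound 1 to compound 3 (1.37 log units; beyond the scatter). Compound 4 `CC(C)(CCCCOc1cc(-c2ccccc2)c2cc(Cl)ccc2n1)C(=O)O` is not yet measured and differs from compound 2 by chloro in place of hydrogen on an aromatic carbon. That is the same kind of change as from compound 1 to compound 3, not the same: there the chlorine sits on a six-membered aromatic ring of carbon only, para to a large group; here it sits on a ring that is part of a fused system of two rings, meta to a fused ring and para to a fused ring. From compound 2 a smaller step is expected, a 2.0-fold lower number from compound 2 to compound 4 (0.31 log units; beyond the scatter), resting on compound 2 at 183 nM and on the earlier 23-fold lower number from compound 1 to compound 3 (1.37 log units; beyond the scatter) made on a different ring. Compound 4 is expected to give 90 nM in this assay.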

Compound 4, half-maximal inhibitory concentration: 2500 nM
Estimate against measurement, compound 4: 28-fold (1.44 log units) below; measured number outside the range, above it.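

In this assay, putting chloro on the fused system of two rings gives a 14-fold higher number from compound 2 to compound 4 (1.14 log units; beyond the scatter), so the gain seen earlier does not carry over. The same swap of hydrogen for chloro moved the number in opposite directions on the two cores: the same change on two cores in this assay, a 23-fold lower number (1.37 log units; beyond the scatter) from compound 1 to compound 3 and a 14-fold higher number (1.14 log units; beyond the scatter) from compound 2 to compound 4, 320-fold (2.50 log units) apart, beyond the scatter of two such steps

The two steps differ both in the chain and in the ring that carries the chlorine, and the compounds shown cannot separate these, so this does not show which of the two reverses the outcome. Still open, going by these compounds, is what chloro does on the fused rings with the chain of compound 1, and on the phenyl ring with the chain of compound 2. Also open, on these data alone, is whether a fluoro or a methoxy group in the place of the chlorine of compound 4 would raise the number as far.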